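Formyl to acetyl on the shared core

This account rests on a few compounds, and the source may have more. Where it says the series, first, only, none or still open, it means among the compounds named here.

Compound 1 `CC(Oc1ccccc1Br)C1=NCCN1` gives 10 nM in a functional assay on CHO cells for agonist activity at Alpha-2C adrenergic receptor (Homo sapiens); on this read-out higher numbers stand for an effect only at larger amounts of compound and lower numbers for an effect already at smaller amounts.
Compound 2 `CCOc1ccccc1OC(C)C1=NCCN1` gives 10000 nM in this assay.
Compound 3 `CC(Oc1ccccc1C=O)C1=NCCN1` gives 100 nM in this assay.

Compound 3 stands second of the three: compound 1 lies a 10-fold higher number from compound 1 to compound 3 (1.00 log units; beyond the scatter) away, while compound 2 is the furthest, at a 100-fold lower number from compound 2 to compound 3 (2.00 log units; beyond the scatter). Compound 4 `CC(=O)c1ccccc1OC(C)C1=NCCN1` differs from compound 3 only by methyl in place of hydrogen on a carbonyl carbon, that is, formyl to acetyl. For the measured compounds named here, no measured step changes a group on the carbonyl carbon, so nothing bears on this change directly. What the measured steps do show is that the group on the aromatic carbon matters: a 1000-fold higher number from compound 1 to compound 2 (3.00 log units; beyond the scatter) and a 10-fold higher number from compound 1 to compound 3 (1.00 log units; beyond the scatter) both lie beyond the scatter. The present change is smaller than any of those, leaving the carbonyl in place and adding a single carbon. Compound 4 is therefore expected to stay near compound 3, with a step of a 1.5-fold higher number from compound 3 to compound 4 (0.18 log units; within the scatter) that may fall within the scatter or be a modest rise. The estimate for compound 4 in this assay is 150 nM, within 30 nM to 1000 nM.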

Compound 4, half-maximal effective concentration: 200 nM
Compound 4: the middle estimate sits 1.3-fold (0.12 log units) below what was measured; low and high end bracket the measured number.
By their numbers in this assay, from the lowest: compound 1; then compounds 3 and 4 (each within the scatter of the next); then compound 2.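

Methyl in place of hydrogen on a carbonyl carbon gives a 2.0-fold higher number from compound 3 to compound 4 (0.30 log units; within the scatter) in this assay on this first change at that carbon, so formyl and acetyl are not told apart here. Replacing ethoxy with acetyl gives a 50-fold lower number from compound 2 to compound 4 (1.70 log units; beyond the scatter) and replacing bromo with acetyl gives a 20-fold higher number from compound 1 to compound 4 (1.30 log units; beyond the scatter) in the same read-out, which places acetyl with formyl, clearly apart from both bromo and ethoxy. Nothing at hand accounts for the size of any of these steps.

Going by these compounds, whether a longer chain, an amine or a hydroxyl on the carbonyl carbon would also leave the number near those of compound 3 and compound 4 stays open. So does the question of where a carboxylic acid or a nitrile on the aromatic carbon would fall relative to bromo, the carbonyl groups and ethoxy.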